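This account rests on a few compounds, and the source may have more. Where it says the series, first, only, none or still open, it means among the compounds named here.

Measured compounds and their values:
compound 1 `COc1ccc([C@@H]2C/C(=N\O)c3c(O)cc(OCc4cn(Cc5ccccc5C)nn4)cc3O2)cc1O` gives 18000 nM in a functional assay on RAW264.7 cells (Mus musculus) for inhibition, read by Griess assay, with stated times of 2 h and 24 h; a lower number here means a stronger inhibitor, a higher number a weaker inhibitor;
compound 2 `COc1ccc([C@@H]2CC(=O)c3c(O)cc(OCc4cn(Cc5ccccc5F)nn4)cc3O2)cc1O` gives 7320 nM in this assay;
compound 3 `COc1ccc([C@@H]2CC(=O)c3c(O)cc(OCc4cn(Cc5ccc(C)cc5)nn4)cc3O2)cc1O` gives 16800 nM in this assay.

Compound 1 has the highest number of the three, although the gap to compound 3 lies within the scatter; only the gap to compound 2 is beyond it. Compound 4 `COc1ccc([C@@H]2C/C(=N\O)c3c(O)cc(OCc4cn(-c5ccccc5)nn4)cc3O2)cc1O` keeps the core of compound 1 and differs in one place: phenyl in place of 2-methylbenzyl on an aromatic nitrogen. Going by the values given here, no measured pair covers this change directly. Among the compounds with values here, the only measured step, a 2.3-fold higher number from compound 2 to compound 3 (0.36 log units; beyond the scatter), swaps one benzyl group for another on the same kind of position in the ketone series, and it is modest. The change from compound 1 to compound 4 is of a different kind, since it removes the saturated chain carbon and puts the phenyl directly on the aromatic nitrogen, so the measured step gives only a rough sense of scale. On that basis a modest shift of the same order is expected in this assay, with its direction uncertain. Compound 4 is therefore estimated at 12000 nM, within a range of 4000 nM to 36000 nM, which corresponds to an expected step of a 1.5-fold lower number from compound 1 to compound 4 (0.18 log units; within the scatter).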

Compound 4, half-maximal inhibitory concentration: 6130 nM
For compound 4 the middle estimate is 2.0-fold (0.29 log units) above the measured one, within the range that was stated.
By their numbers in this assay, from the lowest: compounds 4 and 2 (each within the scatter of the next); then compounds 3 and 1 (each within the scatter of the next).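

In this assay the aromatic nitrogen of the five-membered ring now has a step that changes how the aryl group is attached, and the phenyl group gives a 2.9-fold lower number from compound 1 to compound 4 (0.47 log units; beyond the scatter) and so counts as a gain beyond the scatter, though a modest one. The earlier step, a 2.3-fold higher number from compound 2 to compound 3 (0.36 log units; beyond the scatter) in the ketone compounds, only exchanged one substituted benzyl group for another and kept the saturated chain carbon, so it could not show that this carbon and the methyl group can both leave, taking the group from 8 heavy atoms to 6, with no loss in this assay. Nothing available here accounts for the lower number that comes with this change.

Going by these compounds alone, the single pair leaves the two parts of the change unseparated, since an unsubstituted benzyl group or a 2-methylphenyl group on the same nitrogen would be needed to tell the loss of the chain carbon from the loss of the methyl group. It also leaves open whether phenyl would give a similar step on the ketone core, and how a longer chain such as 2-phenylethyl or a phenyl ring carrying an amine would fare at this position.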